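The source may hold more compounds than are shown below. What is called first, only, known or untested is meant among the compounds shown, and "the series" means these compounds.

Compound 1, `c1ccc2nc(COc3ccc(OCCCc4nnn[nH]4)cc3)ccc2c1`, in a functional assay (lung) for inhibition, with Cavia porcellus as the target (on this read-out lower numbers stand for stronger inhibition and higher numbers for weaker inhibition), gives 250 nM. Compound 2, `O=C(O)CCCOc1ccc(OCc2ccc3ccccc3n2)cc1`, in this assay gives 800 nM. Compound 3, `O=C(O)CCC(Cc1cccc(OCc2ccc3ccccc3n2)c1)c1ccccc1`, in this assay gives 56 nM.

Compounds 2 and 1 differ in one place only: 1H-tetrazol-5-yl in place of carboxy on a saturated chain carbon, three bonds along the chain from an oxygen on an aromatic ring. That change produced a 3.2-fold lower number from compound 2 to compound 1 (0.51 log units; beyond the scatter). Compound 3 shares part of its structure with compound 2, but the difference between the two cores is not broken down here. Among the three, compound 3 stands lowest in this assay, with compound 1 nearest and compound 2 furthest.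

Compound 4, `c1ccc(C(CCc2nnn[nH]2)Cc2cccc(OCc3ccc4ccccc4n3)c2)cc1`, has not yet been measured. It differs from compound 3 in one place: 1H-tetrazol-5-yl in place of carboxy on a saturated chain carbon, three bonds along the chain from an aromatic carbon. Going by the values given here, this is the same kind of change as the one from compound 2 to compound 1, though the place is not identical: there the chain ran from an oxygen on an aromatic ring, here it runs from an aromatic carbon. Resting on a 3.2-fold lower number from compound 2 to compound 1 (0.51 log units; beyond the scatter), the step from compound 3 to compound 4 in this assay is expected to be a 2.5-fold lower number from compound 3 to compound 4 (0.41 log units; beyond the scatter). Compound 4 is therefore estimated at 22 nM, likely between 8 nM and 70 nM.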

Compound 4, half-maximal inhibitory concentration: 24 nM
The estimate for compound 4 lay 1.1-fold (0.04 log units) below the measured number; measured number inside the range.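

Replacing carboxy with 1H-tetrazol-5-yl gave a 2.3-fold lower number from compound 3 to compound 4 (0.37 log units; beyond the scatter) in this assay, so on this second core the swap again goes with stronger inhibition. Set beside the earlier case, the step carried across the two cores in the same direction and at a size that cannot be told apart from the first: the same change on two cores in this assay, a 3.2-fold lower number (0.51 log units; beyond the scatter) from compound 2 to compound 1 and a 2.3-fold lower number (0.37 log units; beyond the scatter) from compound 3 to compound 4, 1.4-fold (0.14 log units) apart, within the scatter of two such steps. Going by these compounds alone, this is only two matched pairs in a single assay, so it supports carrying the change between these two cores but neither proves a rule for the whole series nor explains why the number falls.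

The compounds shown leave open whether the same step would appear on a core with a longer chain between the ring and the 1H-tetrazol-5-yl or carboxy group. They also leave open how a sulfonamide or a methyl ester in that place would compare with either group.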